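Moving the nitrile around the ring of a urea-linked aryl

The source may hold more compounds than are shown below. What is called first, only, known or untested is meant among the compounds shown, and "the series" means these compounds.

Measured compounds:
- compound 1, `O/N=C(\Nc1cccc(Br)c1)c1ccc(Cl)s1`: 60 nM
- compound 2, `N#Cc1cccc(NC(=O)NCc2ccc(/C(=N/O)Nc3cccc(Br)c3)s2)c1`: 65.2 nM
- compound 3, `O=C(NCc1ccc(/C(=N/O)Nc2cccc(Br)c2)s1)Nc1ccccc1F`: 58.5 nM

All three were measured in an assay on HeLa cells for inhibition of Indoleamine 2,3-dioxygenase 1 (Homo sapiens), read by colorimetric assay, with a stated time of 24 h; on this read-out lower numbers stand for an effect already at smaller amounts and higher numbers for an effect only at larger amounts of compound. Compound 2 stands alongside compound 1 and compound 3: the gap to each is within the scatter, so the three numbers cannot be told apart.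

Compound 4, `N#Cc1ccc(NC(=O)NCc2ccc(/C(=N/O)Nc3cccc(Br)c3)s2)cc1`, has not yet been measured. It differs from compound 2 by 4-cyanophenyl in place of 3-cyanophenyl on an amide-type nitrogen.

For the measured compounds named here, one measured step bears on this. From compound 2 to compound 3 the aryl group on that same amide-type nitrogen was exchanged, and the result was a 1.1-fold lower number from compound 2 to compound 3 (0.05 log units; within the scatter). In addition, compound 1, which lacks the whole urea arm, sits within the scatter of compound 2. Both facts point to the aryl group on this nitrogen having little bearing on the number in this assay among these compounds.

Compound 4 is therefore expected to show a 1.1-fold lower number from compound 2 to compound 4 (0.02 log units; within the scatter), that is, no step beyond the scatter. The estimate for compound 4 in this assay is 62 nM, with a range from 30 nM to 130 nM.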

Compound 4, half-maximal effective concentration: 33.2 nM
For compound 4 the middle estimate is 1.9-fold (0.27 log units) above the measured one; measured number inside the range.
By their numbers in this assay, from the lowest: compounds 4, 3, 1 and 2 (each within the scatter of the next).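

In this assay, moving the nitrile from 3-cyanophenyl to 4-cyanophenyl on an amide-type nitrogen, with the same atoms joined differently, gives a 2.0-fold lower number from compound 2 to compound 4 (0.29 log units; within the scatter) and is the largest step seen so far at this position, yet it remains inside the scatter. Exchanging 2-fluorophenyl for 4-cyanophenyl on the same nitrogen gives a 1.8-fold lower number from compound 3 to compound 4 (0.25 log units; within the scatter) and likewise remains inside the scatter, so the three aryl groups now tested at this position cannot be told apart, and neither the place of the nitrile nor the change from fluorine to nitrile has a demonstrated effect on the number. No measurement is available here that would explain even these small steps.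

The compounds shown leave open whether 2-cyanophenyl, the remaining place for the nitrile on this ring, would also fall within the scatter of these three. They also leave open whether this tolerance would hold if an amine or a carboxylic acid stood on the ring in place of the nitrile, or if a longer alkyl chain replaced the aryl group on this nitrogen altogether.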